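The compounds below may be only part of what the source reports. "The series", "measured", "known", "first", "only" and "open" are said of these compounds alone.

Compound 1 `COc1cc2c(Oc3ccc(NC(=O)c4cn(-c5ccccc5)nn4)cc3F)ccnc2cc1OCCCN1CCCCC1` and compound 2 `COc1cc2c(Oc3ccc(NC(=O)c4cn(-c5ccc(F)c(F)c5)nn4)cc3F)ccnc2cc1OCCCN1CCCCC1` share a common core and differ only at the aryl group on the aromatic nitrogen. In a functional assay on MKN-45 cells (Homo sapiens) for cytotoxicity, read by MTT assay, with a stated time of 72 h (a lower number here means a stronger inhibitor, a higher number a weaker inhibitor), compound 1 gives 100 nM, and in the same assay compound 2 gives 310 nM. Among the compounds with values here, the one measured step, a 3.1-fold higher number from compound 1 to compound 2 (0.49 log units; beyond the scatter), places compound 2 as the higher of the two numbers so far, with compound 1 as its only neighbour.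

Compound 3 `COc1cc2c(Oc3ccc(NC(=O)c4cn(-c5ccc(F)c(F)c5)nn4)cc3F)ccnc2cc1OCCCN1CCC(C)CC1` keeps the 3,4-difluorophenyl group of compound 2 and changes elsewhere: methyl in place of hydrogen on a saturated ring carbon. Within the data shown here, no measured step touches that saturated ring; the step of a 3.1-fold higher number from compound 1 to compound 2 (0.49 log units; beyond the scatter) concerns the aryl group on the aromatic nitrogen and does not bear on a methyl added to the ring carbon. With nothing to guide the direction, the small size of the group that enters suggests a step that stays within the usual scatter, and compound 3 is therefore expected to sit near compound 2 in this assay, with the step of a 1.1-fold higher number from compound 2 to compound 3 (0.05 log units; within the scatter) meant as a modest drift at most. Compound 3 is estimated at 350 nM, within a range of 150 nM to 800 nM.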

Compound 3, half-maximal inhibitory concentration: 1290 nM
Compound 3: the middle estimate sits 3.7-fold (0.57 log units) below what was measured, outside the stated range (above it).
By their numbers in this assay, from the lowest: compound 1; then compound 2; then compound 3.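

Within the data shown here, replacing piperidin-1-yl with 4-methylpiperidin-1-yl gives a 4.2-fold higher number from compound 2 to compound 3 (0.62 log units; beyond the scatter) in this assay and shows for the first time that this end of the molecule is not indifferent to change: the earlier step concerned only the aryl group on the aromatic nitrogen, and here a single added carbon, with no ring, no hydrogen-bond donor or acceptor and no net charge, moves the number beyond the scatter. The ring carbon three ring bonds from the ring nitrogen is therefore a second place in the series where a substitution raises the number, in the same direction as the earlier change from phenyl to 3,4-difluorophenyl. Nothing available here explains why the methyl has this effect.

The compounds shown leave open whether any group at this ring carbon would raise the number or whether the result is particular to methyl, as a hydroxyl group or a fluorine atom there would tell. They also leave open how a morpholine or a 4-methylpiperazine in place of the piperidine would read, and whether the methyl acts the same way with the unsubstituted phenyl group of compound 1.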